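The compounds below may be only part of what the source reports. "The series", "measured", "known", "first", "only" and "open" are said of these compounds alone.

Measured so far in an ADME assay on RAW264.7 cells (Mus musculus) for cytotoxicity, read by MTT assay, with a stated time of 72 h, tested at 50 uM; a higher number here means more inhibition at the concentration tested (going by the name of the read-out), a lower number less inhibition:
compound 1 `CCOC(=O)c1sc(-c2ccccc2)nc1N1CCC(NCc2ccc(OCc3ccccc3)cc2)CC1`: 18.4%
compound 2 `CCOC(=O)c1sc(-c2ccccc2)nc1N1CCC(NCc2ccc(C(F)(F)F)cc2)CC1`: 22.7%
compound 3 `CCOC(=O)c1sc(-c2ccccc2)nc1N1CCC(NCc2ccc(Cl)cc2Cl)CC1`: 9.43%

Compound 2 has the highest of the three numbers in this assay, though compound 1 sits within the scatter of it: a number 4.3 percentage points higher from compound 1 to compound 2 (within the scatter). Only compound 3 lies clearly apart, by a number 13.3 percentage points lower from compound 2 to compound 3 (beyond the scatter).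

Compound 4 `CCOC(=O)c1sc(-c2ccncc2)nc1N1CCC(NCc2ccc(C(F)(F)F)cc2)CC1` differs from compound 2 in one place: pyridin-4-yl in place of phenyl on an aromatic carbon. The change sits on an aromatic carbon of a five-membered aromatic ring with 1 nitrogen and 1 sulfur, two ring bonds from the ring atom that bears the ethoxycarbonyl group. Neither measured step bears on this position; both steps alter the group on the saturated chain carbon bound to the amine nitrogen, and they span only a modest range, one within the scatter and one just beyond it. For the measured compounds named here, no measured step informs a change of the phenyl in this part of the core, so nothing beyond the scatter is expected in either direction, with a wide range to cover the uncertainty.

Compound 4 is expected to give about 21% in this assay, between 6% and 38%, meaning an expected step of a number 1.7 percentage points lower from compound 2 to compound 4 (within the scatter).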

Compound 4, a percentage reported as inhibition, at one concentration (the size of the read-out at that concentration, not a potency): 18.1%
Estimate against measurement, compound 4: 2.9 percentage points above, and the stated range covers the measured number.
By their numbers in this assay, from the lowest: compounds 3, 4, 1 and 2 (each within the scatter of the next, the first and the last beyond it).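

In this assay, for the compounds shown here, the first reading on the aromatic carbon next to the ring nitrogen and next to the ring sulfur is a number 4.6 percentage points lower from compound 2 to compound 4 (within the scatter), so pyridin-4-yl in place of phenyl at this carbon leaves the number within the scatter. The earlier steps shown here concerned only the other end of the molecule, and this one shows that a hydrogen-bond acceptor can enter this ring with no step beyond the scatter. No available measurement accounts for the step.

From the compounds shown here alone, whether pyridin-4-yl gives a similar step alongside the benzyloxy group of compound 1 or the 2,4-dichlorophenyl group of compound 3 remains open. Also open, going by these compounds, is how this carbon responds to a different kind of group, such as pyridin-3-yl, a phenyl ring carrying an amine or a carboxylic acid, or a saturated ring such as cyclohexyl.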